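A few compounds are considered here, and "the series" means these few. Any claim that something is new, unique, unknown or untested is made for them only; others in the source may bear on it.

Measured so far:
compound 1, `COc1cc(NS(=O)(=O)c2ccc(N3CCNC3=O)cc2)cc(OC)c1OC` — > 250 nM
compound 2, `COc1cccc(NS(=O)(=O)c2ccc(N3CCNC3=O)cc2)c1` — 700 nM

Of the compounds shown here, two have been tested in a functional assay (CEM-VLB cells, Homo sapiens) for antiproliferative activity, read by sulforhodamine B assay, with a stated time of 48 h; a lower number here means a stronger inhibitor, a higher number a weaker inhibitor. Compound 1 gives only a limit in this assay, > 250 nM, not a number. For the measured compounds named here, compound 2 gives 700 nM, the only firm number there is, so it stands as the sole fixed point. Compound 3, `O=C1NCCN1c1ccc(S(=O)(=O)Nc2cccc(Cl)c2)cc1`, has not been measured. It differs from compound 2 by one change: chloro in place of methoxy on an aromatic carbon. Going by the values given here, no measured pair shows what such a swap does here. The step from compound 2 to compound 3 is expected to be small, a 1.2-fold lower number from compound 2 to compound 3 (0.07 log units; within the scatter), within the usual scatter. For compound 3 the estimate in this assay is 600 nM, between 200 nM and 2000 nM.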

Compound 3, half-maximal inhibitory concentration: 170 nM
Estimate against measurement, compound 3: 3.5-fold (0.55 log units) above; the whole stated range lies above it.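

In this assay, for the compounds shown here, this position proves sensitive to what sits on it: chloro in place of methoxy brings a 4.1-fold lower number from compound 2 to compound 3 (0.61 log units; beyond the scatter) and gives the first readable step. With the rest of the compound unchanged, this one swap moves the number beyond the usual scatter, although a single pair cannot say why. Compound 1 gives only a limit, not a number, so no step can be read from it: the limit of > 250 nM in this assay, at which 1 of the 3 values shown sits.

From the compounds shown here alone, whether fluoro, methyl or an amine at this place would match chloro remains open. So does whether chloro would give a similar gain elsewhere on the ring.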